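Cyclohexyl for cyclopentyl on an amine nitrogen

The compounds below may be only part of what the source reports. "The series", "measured", "known", "first", "only" and "open" are said of these compounds alone.

Compound 1 `O=[N+]([O-])c1ccccc1COc1ccc(OCCOCCNC2CCCCC2)cc1`: 2880 nM
Compound 2 `COC(=O)c1ccc(COc2ccc(OCCOCCNC3CCCC3)cc2)cc1`: 6990 nM

In a functional assay on SK-OV-3 cells (Homo sapiens) for inhibition, read by CCK-8 assay, with a stated time of 70 h (a lower number here means a stronger inhibitor, a higher number a weaker inhibitor), compound 2 has the higher number of the two, so it is the weaker inhibitor, by a gap beyond the scatter. Compound 3 `COC(=O)c1ccc(COc2ccc(OCCOCCNC3CCCCC3)cc2)cc1` keeps the core of compound 2 but carries cyclohexyl in place of cyclopentyl on an amine nitrogen. Going by the values given here, no measured pair shows this change alone. Compound 1 also carries cyclohexyl and gives 2880 nM, but it differs elsewhere too, so it offers only a weak hint. The expected step of a 1.4-fold lower number from compound 2 to compound 3 (0.15 log units; within the scatter) stays within the scatter, if anything toward a lower number. For compound 3 the estimate is 5000 nM, with an expected range of 2200 nM to 11000 nM.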

Compound 3, half-maximal inhibitory concentration: 6220 nM
Compound 3: the middle estimate sits 1.2-fold (0.09 log units) below what was measured; measured number inside the range.
By their numbers in this assay, from the lowest: compound 1; then compounds 3 and 2 (each within the scatter of the next).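

Swapping cyclopentyl for cyclohexyl on the amine nitrogen gives a 1.1-fold lower number from compound 2 to compound 3 (0.05 log units; within the scatter) in this assay and so makes no readable difference at this position. With cyclohexyl held constant, 4-(methoxycarbonyl)phenyl in place of 2-nitrophenyl gives a 2.2-fold higher number from compound 1 to compound 3 (0.33 log units; beyond the scatter) and accounts for a modest gap, so the group at the other end of the molecule matters more here than the ring size on the nitrogen. The data offer no independent measurement that explains either step. Still open, from the compounds shown here alone, is whether a smaller ring such as cyclobutyl or a benzyl group on this nitrogen would shift the number. A carboxylic acid in place of the methyl ester also remains untested in the compounds shown.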